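The source may hold more compounds than are shown below. What is called first, only, known or untested is meant among the compounds shown, and "the series" means these compounds.

Two measured compounds share one core and differ only in the group on a nitrogen that bridges two aromatic rings. Compound 1 `CCN(c1ccnc(Nc2ccc(C#N)cc2)n1)c1c(F)cc(-c2ccc(C#N)cc2)cc1F` carries an ethyl there, and in an ADME assay on MT4 cells (Homo sapiens) for cytotoxicity, read by MTT assay, with a stated time of 5 days (a lower number here means that less compound is tolerated, a higher number that more compound is tolerated), compound 1 gives 105000 nM. Compound 2 `N#Cc1ccc(Nc2nccc(N(CCCO)c3c(F)cc(-c4ccc(C#N)cc4)cc3F)n2)cc1` carries a 3-hydroxypropyl instead, and in this assay compound 2 gives 68000 nM. The step of a 1.5-fold lower number from compound 1 to compound 2 (0.19 log units; within the scatter) is the only measured one, and it lies within the scatter, so compound 2 and compound 1 give numbers that cannot be told apart. Compound 3 `CC(=O)N(c1ccnc(Nc2ccc(C#N)cc2)n1)c1c(F)cc(-c2ccc(C#N)cc2)cc1F` has not yet been measured. It differs from compound 2 by acetyl in place of 3-hydroxypropyl on a nitrogen on an aromatic ring. Within the data shown here, no measured step swaps a chain for an acetyl. Among the measured compounds shown here, the one step on record changed the group at this same nitrogen and moved the number by a 1.5-fold lower number from compound 1 to compound 2 (0.19 log units; within the scatter), which stayed within the scatter. For the measured compounds named here, with that as the only guide, for compound 3 the expected step is a 1.2-fold higher number from compound 2 to compound 3 (0.07 log units; within the scatter), not beyond the scatter in either direction. For compound 3 the estimate in this assay is 80000 nM, with a range from 30000 nM to 200000 nM.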

Compound 3, half-maximal cytotoxic concentration: > 268000 nM
Compound 3 was reported as a limit (the forecaster's own chance of this, stated with the estimate: 20%); middle value at least 3.3-fold (0.52 log units) away from the limit.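

In this assay, the group on this nitrogen can move the number beyond the scatter: placing acetyl there gives an at least 3.9-fold higher number from compound 2 to compound 3 (0.59 log units; beyond the scatter), and against the ethyl chain it gives an at least 2.5-fold higher number from compound 1 to compound 3 (0.40 log units; beyond the scatter). The ethyl chain carries no hydroxyl either, and the step of a 1.5-fold lower number from compound 1 to compound 2 (0.19 log units; within the scatter) stays within the scatter, so the loss of the hydroxyl alone does not account for what is seen with acetyl. The value for compound 3 is a limit of the assay and not a number: the limit of > 268000 nM in this assay, at which 1 of the 3 values shown sits.

From the compounds shown here alone, how far compound 3 really lies from the other two stays unknown, so both step sizes are lower bounds only. The compounds shown also do not tell whether a propanoyl or a benzoyl group on this nitrogen, or a chain carrying an amine, would fall with acetyl or with the two chains.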